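Amide cap change on a cytotoxicity-inactive core

The compounds below may be only part of what the source reports. "The series", "measured", "known", "first", "only" and "open" are said of these compounds alone.

Compound 2 has the structure `O=C(NCc1ccccc1)c1cccc(/C=C2\CC(=O)N(c3ccccc3)C2=O)c1`. In an ADME assay on SW480 cells (Homo sapiens) for cytotoxicity, read by MTT assay, with a stated time of 72 h (on this read-out lower numbers stand for stronger inhibition and higher numbers for weaker inhibition), compound 2 reaches only a limit, > 100000 nM. Its neighbour compound 1, with the structure `Cc1ccc(NC(=O)c2cccc(/C=C3\CC(=O)N(c4ccccc4)C3=O)c2)cc1C`, differs from it in one place: benzyl in place of 3,4-dimethylphenyl on an amide-type nitrogen. In this assay compound 1 likewise stops at a limit, > 100000 nM. The step that the two limits leave unreadable from compound 1 to compound 2 therefore cannot be read as a number, since (the limit of > 100000 nM in this assay, at which 2 of the 2 values shown sit).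

Compound 3, with the structure `COc1ccc(OC)c(NC(=O)c2cccc(/C=C3\CC(=O)N(c4ccccc4)C3=O)c2)c1`, carries the change (2,5-dimethoxyphenyl in place of benzyl on an amide-type nitrogen). Among the measured compounds shown here, the one measured step on the same amide-type nitrogen, from compound 1 to compound 2, gives no size at all, so there is nothing to say that an aryl cap of any kind moves the read-out; both caps tried so far leave the compound at the limit. The step that the limit leaves unreadable from compound 2 to compound 3 is thus expected to stay unreadable, with compound 3 most likely again at the limit. The estimate for compound 3 is 150000 nM, within 50000 nM to 500000 nM.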

Compound 3, half-maximal inhibitory concentration: > 100000 nM
Compound 3: no number, only a limit; the forecaster's own chance of this, stated with the estimate: 80%; the middle value does not contradict the limit.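

In this assay compound 3 gives > 100000 nM, which is a limit and not a number. No step among compound 1, compound 2 and compound 3 can be read as a size, because all three stop at the same limit: the limit of > 100000 nM in this assay, at which 3 of the 3 values shown sit.

The compounds shown leave open whether any cap on this amide-type nitrogen can give a measurable value on the shared core.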